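Working notes: tert-butyl in place of phenyl

The source may hold more compounds than are shown below. What is called first, only, known or untested is meant among the compounds shown, and "the series" means these compounds.

- compound 1 `c1cc(NC2=NCCO2)cc(OC2CCCC2)c1`: 62100 nM
- compound 2 `Ic1ccc(NC2=NCCO2)cc1`: 2900 nM
- compound 3 `O=C(CCl)NC(=O)Nc1ccc(-c2ccccc2)cc1`: 3900 nM

All three numbers come from a functional assay on MCF7 cells (Homo sapiens) for inhibition, read by sulforhodamine B assay, with a stated time of 48 h; on this read-out lower numbers stand for stronger inhibition of growth and higher numbers for weaker inhibition of growth. Compound 3 lies within the scatter of compound 2, so these two are not separated. Compound 1 has a higher number than compound 3, and that gap lies beyond the scatter.

The next compound is compound 4 `CC(C)(C)c1ccc(NC(=O)NC(=O)CCl)cc1`, which carries tert-butyl in place of phenyl on an aromatic carbon. Within the data shown here, no pair of measured compounds shows this change, and compound 3 is the only measured compound with this core. The expectation therefore rests on compound 3 at 3900 nM and on the structural change alone. In this assay no step beyond the scatter is expected, with only a slight lean towards a higher number. The expected step is a 1.3-fold higher number from compound 3 to compound 4 (0.11 log units; within the scatter). For compound 4 the estimated value is 5000 nM, with an expected range of 1800 nM to 14000 nM.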

Compound 4, concentration for 50% growth inhibition: 4800 nM
Compound 4: middle estimate off by 1.0-fold (0.02 log units), on the high side, and the stated range covers the measured number.
By their numbers in this assay, from the lowest: compounds 2, 3 and 4 (each within the scatter of the next); then compound 1.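

In this assay, the exchange of phenyl for tert-butyl on an aromatic carbon, para to a group of 8 heavy atoms, gives a 1.2-fold higher number from compound 3 to compound 4 (0.09 log units; within the scatter), so the two compounds are not separated. Among these compounds, this is the first direct read on this position: for this pair, the six-membered aromatic ring of carbon only can give way to a ringless group of 4 heavy atoms without a step beyond the scatter. No measurement here accounts for this result.

Among the compounds shown here, the pair covers only two carbon-only groups, each with 0 hydrogen-bond donors and 0 hydrogen-bond acceptors, so one flat step does not describe the position as a whole. As far as these compounds go, the effect of an amine or a carboxylic acid on this aromatic carbon remains open.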